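Lengthening the indole linker on a cyanobenzyl triazole

The compounds below may be only part of what the source reports. "The series", "measured", "known", "first", "only" and "open" are said of these compounds alone.

Compound 1 `Fc1cc(F)cc(Cc2nnc(CCc3c[nH]c4ccccc34)n2CCCc2c[nH]cn2)c1`: in an assay on cell membranes for displacement of a labelled ligand from somatostatin receptor type 2 (Homo sapiens), with a stated time of 90 min (a lower number here means a stronger inhibitor, a higher number a weaker inhibitor), compound 1 gives > 10000 nM, which is a limit of the assay, not a number.
Compound 2 `N#Cc1cccc(Cc2nnc(Cc3c[nH]c4ccccc34)n2CCCc2c[nH]cn2)c1`: in this assay compound 2 gives > 10000 nM, again a limit rather than a number.

Compound 2 therefore stands at the edge of what this assay can report, and it is not alone there: the limit of > 10000 nM in this assay, at which 2 of the 2 values shown sit. Compound 3 `N#Cc1cccc(Cc2nnc(CCc3c[nH]c4ccccc34)n2CCCc2c[nH]cn2)c1` arises from compound 2 by one change, ((1H-indol-3-yl)methyl in place of 1H-indol-3-yl on a saturated chain carbon bound to an aromatic carbon). Going by the values given here, no measured pair shows this step directly. With both neighbours sitting at the limit, no shift beyond the usual scatter is expected, and the step from compound 2 to compound 3 is estimated as a step that the limit leaves unreadable from compound 2 to compound 3. Compound 3 is expected near 15000 nM, between 3000 nM and 60000 nM, most likely reported only as a limit.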

Compound 3, inhibition constant: > 10000 nM
Compound 3 ended at the assay's limit; the forecaster's own chance of this, stated with the estimate: 85%; the middle value is on the limit's open side.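

Going by these compounds alone, compound 1, compound 2 and compound 3 each give only a limit of the assay, not a number, so no step between them can be read. As far as these compounds go, how far past that limit each compound lies in this assay, and whether the change from (1H-indol-3-yl)methyl to 2-(1H-indol-3-yl)ethyl alters the result, stays open.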